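The source may report more compounds than this note shows. Statements on the series, on what has been measured and on what is new or still open speak of the compounds shown alone.

In an assay on CHO cells for displacement of a labelled ligand from Substance-P receptor (Homo sapiens), in the presence of a further agent that is not named here (on this read-out lower numbers stand for stronger inhibition and higher numbers for weaker inhibition), compound 1 `C[C@@H](O[C@H]1CN2C(=O)C=C(c3ccncc3)CC2[C@@H]1c1ccc(F)cc1)c1cc(C(F)(F)F)cc(C(F)(F)F)c1` gives 8.1 nM, compound 2 `C[C@@H](O[C@H]1CN2C(=O)C=C(c3cc[n+]([O-])cc3)CC2[C@@H]1c1ccc(F)cc1)c1cc(C(F)(F)F)cc(C(F)(F)F)c1` gives 2.1 nM and compound 3 `Cc1cc(C2=CC(=O)N3C[C@H](O[C@H](C)c4cc(C(F)(F)F)cc(C(F)(F)F)c4)[C@@H](c4ccc(F)cc4)C3C2)ccn1` gives 34 nM; compound 3 stands highest of the three numbers. The steps seen so far are a 3.9-fold lower number from compound 1 to compound 2 (0.59 log units; beyond the scatter), a 4.2-fold higher number from compound 1 to compound 3 (0.62 log units; beyond the scatter) and a 16-fold higher number from compound 2 to compound 3 (1.21 log units; beyond the scatter). Compound 4 `C[C@@H](O[C@H]1CN2C(=O)C=C(c3cnn(C)c3)CC2[C@@H]1c1ccc(F)cc1)c1cc(C(F)(F)F)cc(C(F)(F)F)c1` carries 1-methyl-1H-pyrazol-4-yl in place of 2-methylpyridin-4-yl on a double-bonded ring carbon. Going by the values given here, no measured step exchanges one ring for another at this position, so none bears on it directly; the pyridine steps only show that changes here move this assay by modest to large amounts in both directions, with compound 3 at the high end. For compound 4 the expected step in this assay is a 3.4-fold lower number from compound 3 to compound 4 (0.53 log units; beyond the scatter). Compound 4 is estimated at 10 nM in this assay, within 3 nM to 35 nM.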

Compound 4, half-maximal inhibitory concentration: 5.4 nM
Beside the measured number, compound 4's estimate is 1.9-fold (0.27 log units) above it; measured number inside the range.
By their numbers in this assay, from the lowest: compound 2; then compounds 4 and 1 (each within the scatter of the next); then compound 3.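

In this assay a five-membered aromatic ring is accepted on this double-bonded ring carbon: 1-methyl-1H-pyrazol-4-yl for pyridin-4-yl gives a 1.5-fold lower number from compound 1 to compound 4 (0.18 log units; within the scatter) and for 2-methylpyridin-4-yl gives a 6.3-fold lower number from compound 3 to compound 4 (0.80 log units; beyond the scatter). The oxygen-bearing six-membered ring still holds the lowest number of the set, with a 2.6-fold higher number from compound 2 to compound 4 (0.41 log units; beyond the scatter). Nothing measured here accounts for these steps. Open, as far as these compounds go, is how far the five-membered ring can be varied: whether the pyrazole without its methyl, with a longer chain such as ethyl on its nitrogen, or with an amine on the ring keeps this level.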